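The source may hold more compounds than are shown below. What is called first, only, known or untested is meant among the compounds shown, and "the series" means these compounds.

- compound 1 `Cc1cccc(-c2cc(-c3ccoc3)cc(-c3ccc(Cl)s3)n2)c1` gives 20300 nM
- compound 2 `Cc1ccc(-c2cc(-c3ccoc3)cc(-c3ccc(Cl)s3)n2)cc1` gives 25300 nM
- compound 3 `Clc1ccc(-c2cc(-c3ccoc3)cc(-c3ccccc3Cl)n2)s1` is not yet measured

In a functional assay on DU-145 cells (Homo sapiens) for cytotoxicity, read by ELISA, with a stated time of 4 days (a lower number here means a stronger inhibitor, a higher number a weaker inhibitor), compound 2 gives 25300 nM and stands level with compound 1 within the scatter. Compound 3 has 2-chlorophenyl in place of 4-methylphenyl, next to the ring nitrogen 2-chlorophenyl in place of 4-methylphenyl on an aromatic carbon on the shared core. Among the measured compounds shown here, the only measured step, a 1.2-fold higher number from compound 1 to compound 2 (0.10 log units; within the scatter), exchanges 3-methylphenyl for 4-methylphenyl and says nothing directly about 2-chlorophenyl. No change beyond the scatter is therefore expected, and the estimated step is a 1.3-fold lower number from compound 2 to compound 3 (0.10 log units; within the scatter) on this thin evidence. Compound 3 is estimated at 20000 nM with an expected range from 8000 nM to 50000 nM for a single measurement.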

Compound 3, half-maximal inhibitory concentration: 16400 nM
Estimate against measurement, compound 3: 1.2-fold (0.09 log units) above; the range from low to high includes it.
By their numbers in this assay, from the lowest: compounds 3, 1 and 2 (each within the scatter of the next).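

In this assay, placing 2-chlorophenyl next to the ring nitrogen gives a 1.5-fold lower number from compound 2 to compound 3 (0.19 log units; within the scatter), and against the other methylphenyl compound it gives a 1.2-fold lower number from compound 1 to compound 3 (0.09 log units; within the scatter). So this position now tolerates a chlorine-bearing phenyl as well as either methylphenyl, with all three numbers level within the scatter. Nothing measured here offers an explanation for this flat result.

All three compounds carry a substituted phenyl at this position. On these data alone, whether an amine, a carboxylic acid or a longer chain there would move the number beyond the scatter remains open.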